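Acetyl for Methyl: Expecting the Cytotoxicity of Compound 4

The source may report more compounds than this note shows. Statements on the series, on what has been measured and on what is new or still open speak of the compounds shown alone.

Of the compounds shown here, three built on one shared core have been tested in an ADME assay on MT4 cells (Homo sapiens) for cytotoxicity, read by MTT assay; on this read-out lower numbers stand for higher toxicity in this test and higher numbers for lower toxicity in this test. Compound 1 `COC(=O)c1ccc(NC(=O)CSc2nncnc2-c2ccccc2Cl)c(Br)c1` gives 59000 nM, compound 3 `O=C(CSc1nncnc1-c1ccccc1Cl)Nc1ccc(Cl)cc1Cl` gives 51000 nM, and compound 2 `Cc1ccc(NC(=O)CSc2nncnc2-c2cccc3ccccc23)c(Br)c1` gives 166000 nM. Compound 2 therefore stands at the highest number of the three. Its gaps to compound 1 and to compound 3 both lie beyond the usual scatter of repeated measurements, so it is the least toxic of the three in this test.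

Compound 4 `CC(=O)c1ccc(NC(=O)CSc2nncnc2-c2cccc3ccccc23)c(Br)c1` differs from compound 2 in one place: acetyl in place of methyl on an aromatic carbon. Among the measured compounds shown here, no measured pair shows this same change, and compound 1 and compound 3 differ from compound 2 in several places at once, so their lower numbers give no direct guide to the size of the step. The step from compound 2 to compound 4 is expected to be a 1.7-fold lower number from compound 2 to compound 4 (0.22 log units; within the scatter), a modest move toward higher toxicity that may not clearly exceed the scatter. Compound 4 is thus expected to give about 100000 nM, within a range from 40000 nM to 250000 nM.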

Compound 4, half-maximal cytotoxic concentration: 133000 nM
Compound 4: middle estimate off by 1.3-fold (0.12 log units), on the low side; the measured number falls inside the stated range.
By their numbers in this assay, from the lowest: compounds 3 and 1 (each within the scatter of the next); then compounds 4 and 2 (each within the scatter of the next).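

In this assay, the first direct view of this change, acetyl in place of methyl gives a 1.2-fold lower number from compound 2 to compound 4 (0.10 log units; within the scatter), so the two compounds cannot be told apart in this test. The aromatic carbon meta to the bromo group and para to a large group therefore carries the larger acetyl, with its hydrogen-bond acceptor, without a clear shift in the read-out. Nothing measured here offers an explanation for this outcome.

The compounds shown leave open whether an amine, a carboxylic acid or a longer chain on this same carbon would move the number beyond the usual scatter. This single pair also leaves open whether acetyl in place of methyl would behave the same way with the other groups found in compound 1 and compound 3.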